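The source may hold more compounds than are shown below. What is called first, only, known or untested is meant among the compounds shown, and "the series" means these compounds.

Three compounds have been measured in a functional assay on HeLa cells (Homo sapiens) for antiproliferative activity, read by sulforhodamine B assay, with a stated time of 48 h; a lower number here means a stronger inhibitor of growth, a higher number a weaker inhibitor of growth:
compound 1 `O=C(NCc1cn(Cc2ccc(C(F)(F)F)cc2)nn1)c1cn(-c2ccccc2)nc1-c1ccc(F)cc1` gives 250 nM;
compound 2 `COc1ccc(Cn2cc(CNC(=O)c3cn(-c4ccccc4)nc3-c3ccc(F)cc3)nn2)cc1` gives 870 nM;
compound 3 `COc1ccc(Cn2cc(CNC(=O)c3cn(-c4ccccc4)nc3-c3ccc(F)cc3)nn2)cc1OC` gives 200 nM.

Compound 2 stands highest of the three numbers, and so is the weakest growth inhibitor of the set: the step of a 3.5-fold higher number from compound 1 to compound 2 (0.54 log units; beyond the scatter) and the step of a 4.4-fold lower number from compound 2 to compound 3 (0.64 log units; beyond the scatter) both lie beyond the scatter. Compound 4 `COc1ccc(Cn2cc(CNC(=O)c3cn(-c4ccccc4)nc3-c3ccc(Cl)cc3)nn2)cc1` has not yet been measured. It differs from compound 2 by chloro in place of fluoro on an aromatic carbon. This change sits on a different ring from the one altered in every measured step: a 3.5-fold higher number from compound 1 to compound 2 (0.54 log units; beyond the scatter) exchanges one group for another on the ring carrying the methoxy, a 4.4-fold lower number from compound 2 to compound 3 (0.64 log units; beyond the scatter) adds a second methoxy to that same ring, and a 1.3-fold lower number from compound 1 to compound 3 (0.10 log units; within the scatter) combines both. None of them touches the fluoro that is exchanged here, so the measured steps give no direct guide to this change. With nothing pointing either way, the expectation is no step beyond the scatter. Compound 4 is estimated at 800 nM, with a likely range from 300 nM to 2500 nM. The step implied by this estimate, a 1.1-fold lower number from compound 2 to compound 4 (0.04 log units; within the scatter), is expected to stay within the scatter.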

Compound 4, concentration for 50% growth inhibition: 1400 nM
The estimate for compound 4 lay 1.8-fold (0.24 log units) below the measured number, within the range that was stated.
By their numbers in this assay, from the lowest: compounds 3 and 1 (each within the scatter of the next); then compounds 2 and 4 (each within the scatter of the next).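

Going by these compounds alone, compound 2 and compound 4 differ only in 4-fluorophenyl versus 4-chlorophenyl, and this exchange gives the only reading at this position: in this assay it produces a 1.6-fold higher number from compound 2 to compound 4 (0.21 log units; within the scatter). Changes on the ring carrying the methoxy had already produced steps beyond the scatter, namely a 3.5-fold higher number from compound 1 to compound 2 (0.54 log units; beyond the scatter) and a 4.4-fold lower number from compound 2 to compound 3 (0.64 log units; beyond the scatter), whereas this halogen exchange, on a different ring, shows no difference that can be told apart from the scatter. No measurement at hand explains why the two compounds read alike.

Within the data shown here, this exchange is seen only with the single methoxy of compound 2, so it remains open whether it would read the same alongside the two methoxy groups of compound 3 or the trifluoromethyl of compound 1. On these data alone, it also remains open how this position would respond to a group other than a halogen, such as an amine or a carboxylic acid, since two closely related atoms say little about the wider range of groups that might sit there.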